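From Methyl to Ethoxycarbonyl on the Shared Core

A few compounds are considered here, and "the series" means these few. Any claim that something is new, unique, unknown or untested is made for them only; others in the source may bear on it.

Compound 1 `c1ccc(/N=c2\ssnc2-c2ccccc2)cc1`: in a functional assay on MDA-MB-231 cells (Homo sapiens) for antiproliferative activity, read by MTT assay, with a stated time of 72 h (on this read-out lower numbers stand for stronger inhibition of growth and higher numbers for weaker inhibition of growth), compound 1 gives > 10000 nM, which is a limit of the assay and not a number.
Compound 2 `Cc1nss/c1=N\c1ccccc1`: in this assay compound 2 gives > 10000 nM, again a limit of the assay.

Compound 2 therefore stands at the edge of what this assay can report, and compound 1 stands there too: the limit of > 10000 nM in this assay, at which 2 of the 2 values shown sit. For the measured compounds named here, the one measured step, a step that the two limits leave unreadable from compound 1 to compound 2, in which methyl replaces phenyl on an aromatic carbon, is of unreadable size; both of its ends are limits, so no direction and no magnitude can be taken from it.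

Compound 3 `CCOC(=O)c1nss/c1=N\c1ccccc1` differs from compound 2 in one place: ethoxycarbonyl in place of methyl on an aromatic carbon. Going by the values given here, no measured step bears on this exchange in a readable way, so the expectation rests on where compound 2 sits. Compound 3 is expected to remain near the limit, with a step that the limit leaves unreadable from compound 2 to compound 3 that is estimated to stay within the usual scatter. The estimate for compound 3 in this assay is 15000 nM, expected to fall between 3000 nM and 60000 nM.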

Compound 3, concentration for 50% growth inhibition: > 10000 nM
Compound 3 was reported as a limit (the forecaster's own chance of this, stated with the estimate: 70%); the middle value does not contradict the limit.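

For the compounds shown here, compound 1, compound 2 and compound 3 all rest at a limit of this assay and not at numbers, so no step among them can be read: the limit of > 10000 nM in this assay, at which 3 of the 3 values shown sit.

Left open is how far apart phenyl, methyl and ethoxycarbonyl on the shared core lie in growth inhibition, both in size and in direction.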